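The source may report more compounds than this note shows. Statements on the series, on what has been measured and on what is new or still open speak of the compounds shown alone.

Compound 1, `Cc1nc(S(C)(=O)=O)ccc1Oc1ncnc(OC2CCN(C(=O)OC(C)(C)CF)CC2)c1F`, in a functional assay on isolated protein for inhibition of Glucose-dependent insulinotropic receptor (Rattus norvegicus), read by HTRF and cAMP accumulation; on this read-out higher numbers stand for an effect only at larger amounts of compound and lower numbers for an effect already at smaller amounts: 138 nM
Compound 2, `Cc1nc(S(C)(=O)=O)ccc1Oc1ncnc(OC2CCN(C(=O)O[C@H](C)C(F)(F)F)CC2)c1F`, in this assay: 110 nM
Compound 3, `Cc1nc(S(C)(=O)=O)ccc1Oc1ncnc(OC2CCN(C(=O)SC(C)(C)C)CC2)c1F`, in this assay: 30.7 nM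

Compound 2 stands second highest of the three numbers in this assay; its nearest neighbour is compound 1, with a 1.3-fold lower number from compound 1 to compound 2 (0.10 log units; within the scatter), and the furthest is compound 3, with a 3.6-fold lower number from compound 2 to compound 3 (0.55 log units; beyond the scatter). Compound 4, `CCc1cnc(C(=O)N2CCC(Oc3ncnc(Oc4ccc(S(C)(=O)=O)nc4C)c3F)CC2)nc1`, is not yet measured; it differs from compound 2 by 5-ethylpyrimidin-2-yl in place of 1-(trifluoromethyl)ethoxy on a carbonyl carbon. Going by the values given here, no measured step exchanges an oxygen-linked group on the carbonyl carbon for an aromatic ring. Among the compounds with values here, the steps that bear on this carbonyl substituent are a 1.3-fold lower number from compound 1 to compound 2 (0.10 log units; within the scatter), within the scatter, and a 4.5-fold lower number from compound 1 to compound 3 (0.65 log units; beyond the scatter) together with a 3.6-fold lower number from compound 2 to compound 3 (0.55 log units; beyond the scatter), both modest. They show that one oxygen-linked group for another left the number within the scatter, while the sulfur-linked group gave a modestly lower number; what an aromatic ring does here is not shown. For compound 4 the expected step is a 1.8-fold lower number from compound 2 to compound 4 (0.26 log units; within the scatter), toward a lower number but uncertain. Compound 4 is estimated at 60 nM, with a range from 15 nM to 250 nM.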

Compound 4, half-maximal effective concentration: 40.8 nM
Compound 4: middle estimate off by 1.5-fold (0.17 log units), on the high side; the measured number falls inside the stated range.
By their numbers in this assay, from the lowest: compounds 3 and 4 (each within the scatter of the next); then compounds 2 and 1 (each within the scatter of the next).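

In this assay, an aromatic ring now sits on the carbonyl carbon, and 5-ethylpyrimidin-2-yl in place of 1-(trifluoromethyl)ethoxy gives a modest gain (a 2.7-fold lower number from compound 2 to compound 4 (0.43 log units; beyond the scatter)), with a step of like size against the other oxygen-linked group (a 3.4-fold lower number from compound 1 to compound 4 (0.53 log units; beyond the scatter)). The ring and the (tert-butyl)sulfanyl group cannot be told apart here (a 1.3-fold higher number from compound 3 to compound 4 (0.12 log units; within the scatter)), so among these four compounds, both stand apart from the two oxygen-linked groups, and this position accepts a ring as well as an open-chain group. No measurement bears on why these steps arise.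

From the compounds shown here alone, whether the ethyl group on the pyrimidine contributes remains open, as a methyl, a propyl chain or an unsubstituted pyrimidine would be needed to show it. Equally open, going by these compounds, is how a plain phenyl ring or a nitrogen-linked group such as a dimethylamino group would compare on the carbonyl carbon.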